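Hydroxylation of the compound 1 core: cytotoxicity outlook

This account rests on a few compounds, and the source may have more. Where it says the series, first, only, none or still open, it means among the compounds named here.

Compound 1 `C=C1C[C@]23C[C@@]1(O)CC[C@H]2[C@@]12C=C[C@H](O)[C@@](C)(C(=O)O1)[C@H]2[C@@H]3C(=O)OC` is one of two measured members of the series. In a functional assay on Hs-578T cells (Homo sapiens) for cytotoxicity, read by luminescence and CellTiter-Glo, with a stated time of 24 h (on this read-out higher numbers stand for weaker inhibition and lower numbers for stronger inhibition), compound 1 gives > 10000 nM, which is a limit of the assay and not a number. Compound 2 `C=C1C[C@]23C[C@@]1(O)CC[C@H]2c1cc2c(C(=O)OC)coc2c(C)c1[C@@H]3C(=O)OC` belongs to the same series; in this assay compound 2 gives > 10000 nM, again a limit of the assay rather than a number. Among the measured compounds shown here, compound 1 thus stands at the limit where every value shown sits, as the limit of > 10000 nM in this assay, at which 2 of the 2 values shown sit, records, and no measured step between compounds exists to set a scale for the series.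

Compound 3 `C=C1[C@@H](O)[C@]23C[C@@]1(O)CC[C@H]2[C@@]12C=C[C@H](O)[C@@](C)(C(=O)O1)[C@H]2[C@@H]3C(=O)OC` is not yet measured. It differs from compound 1 by hydroxy in place of hydrogen on a saturated ring carbon. For the measured compounds named here, with no measured step in hand, and with both values shown sitting at the limit, the expected step that the limit leaves unreadable from compound 1 to compound 3 is none beyond the scatter. For compound 3 in this assay the estimate is 15000 nM, with a range from 5000 nM to 50000 nM, and a further limit rather than a number is the most likely outcome.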

Compound 3, half-maximal inhibitory concentration: > 10000 nM
Compound 3: only a limit was reported; the forecaster's own chance of this, stated with the estimate: 80%; the middle value lies beyond the limit too.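

No step can be read from compound 1 to compound 3, since both stand at a limit and not at a number: the limit of > 10000 nM in this assay, at which 3 of the 3 values shown sit.

The compounds shown leave open whether hydroxy in place of hydrogen on a saturated ring carbon alters the response in this assay at all.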